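The compounds below may be only part of what the source reports. "The series", "measured", "known", "first", "only" and "open" are said of these compounds alone.

In an ADME assay on Huh-7 cells (Homo sapiens) for cytotoxicity, with a stated time of 72 h (a higher number here means that more compound is tolerated, a lower number that less compound is tolerated), compound 3 `CS(=O)(=O)Nc1ccc2c(c1)S(=O)(=O)N=C(c1c(O)c(-c3cccs3)nn(CC3(C(F)(F)F)CCC3)c1=O)N2` gives > 1000 nM, which is a limit and not a number. Compound 1 `CCC(C)CCn1nc(-c2cccs2)c(O)c(C2=NS(=O)(=O)c3cc(NS(C)(=O)=O)ccc3N2)c1=O` gives > 1000 nM, which is also a limit. Compound 2 `COC(C)(C)CCn1nc(-c2cccs2)c(O)c(C2=NS(=O)(=O)c3cc(NS(C)(=O)=O)ccc3N2)c1=O` gives > 33000 nM, again a limit. On these data alone, compound 3 therefore sits at the limit of > 1000 nM in this assay, at which 2 of the 3 values shown sit, and its true value is unknown.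

Compound 4 `CS(=O)(=O)Nc1ccc2c(c1)S(=O)(=O)N=C(c1c(O)c(-c3cccs3)nn(CCC3CCC3)c1=O)N2` differs from compound 3 in one group: cyclobutylmethyl in place of 1-(trifluoromethyl)cyclobutyl on a saturated chain carbon bound to an aromatic nitrogen. In words, cyclobutylmethyl stands in place of 1-(trifluoromethyl)cyclobutyl on a saturated chain carbon bound to an aromatic nitrogen.

Two measured steps change this same chain: a step that the two limits leave unreadable from compound 1 to compound 3 and a step that the two limits leave unreadable from compound 2 to compound 3. Neither gives a size, so neither gives a direction. All three measured compounds, with their different chains, end in limits and none gives a number, so the expectation is a compound that is similarly well tolerated. The expected step is a step that the limit leaves unreadable from compound 3 to compound 4, a loose estimate with no firm direction.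

Compound 4 is estimated at 15000 nM, with an expected range from 2000 nM to 50000 nM.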

Compound 4, half-maximal cytotoxic concentration: > 1000 nM
Compound 4: a limit, no number; the forecaster's own chance of this, stated with the estimate: 85%; the middle value is on the limit's open side.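

Among the compounds shown here, compound 4 gives > 1000 nM, which is a limit and not a number, so no step between it and compound 1, compound 2 or compound 3 can be read. The compounds shown leave open the true tolerated concentration of all four, and whether their different chains change it at all.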